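Removing the piperazine methyl across two different cores

The source may hold more compounds than are shown below. What is called first, only, known or untested is meant among the compounds shown, and "the series" means these compounds.

In a functional assay on KB cells (Homo sapiens) for antiproliferative activity, read by MTT assay (a higher number here means a weaker inhibitor, a lower number a stronger inhibitor), compound 1, `c1ccc2c(c1)ccn2-c1nc(N2CCNCC2)nc2ccccc12`, gives 4 ug/mL. Compound 2, `CN1CCN(c2nc(-n3ccc4ccccc43)c3ccccc3n2)CC1`, shares the same core and gives 4.9 ug/mL in this assay. The two differ at one point only:

hydrogen in place of methyl on an amine nitrogen in a ring

That change made a 1.2-fold lower number from compound 2 to compound 1 (0.09 log units; within the scatter), so the two values show no difference that can be trusted.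

Compound 3, `COc1cc(OC)c(-c2nc(N3CCN(C)CC3)nc3ccccc23)c(OC)c1`, carries a different core, and the difference between the two cores is not broken down here. In this assay compound 3 gives 50 ug/mL, the highest of the three numbers, a gap beyond the scatter from both compound 2 and compound 1.

Compound 4, `COc1cc(OC)c(-c2nc(N3CCNCC3)nc3ccccc23)c(OC)c1`, has not been measured. It is related to compound 3 in the same way that compound 1 is related to compound 2:

hydrogen in place of methyl on an amine nitrogen in a ring

The place of the change is the same in both pairs, so this is the same change carried onto the core of compound 3. Because the only measured instance of it gave a 1.2-fold lower number from compound 2 to compound 1 (0.09 log units; within the scatter), a step within the scatter, the expectation for compound 4 is a step of similar size, a 1.1-fold lower number from compound 3 to compound 4 (0.05 log units; within the scatter), with no evidence from the compounds shown that the core of compound 3 would respond differently. Compound 4 is therefore estimated at 45 ug/mL in this assay, with a plausible range from 25 ug/mL to 90 ug/mL.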

Compound 4, half-maximal inhibitory concentration: 50 ug/mL
Estimate against measurement, compound 4: 1.1-fold (0.05 log units) below; the measured number falls inside the stated range.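

Going from 4-methylpiperazin-1-yl to piperazin-1-yl on the core of compound 3 gave no change at the digits printed from compound 3 to compound 4 (within the scatter) in this assay, so the step that was small on the first core is just as small on the second. Set side by side, the two steps do not differ by more than repeated measurements would, and the change therefore carries over from one core to the other without any readable shift in this assay: the same change on two cores in this assay, a 1.2-fold lower number (0.09 log units; within the scatter) from compound 2 to compound 1 and no change at the digits printed (within the scatter) from compound 3 to compound 4, 1.2-fold (0.09 log units) apart, within the scatter of two such steps

This shows only that swapping methyl for hydrogen on that ring nitrogen has no readable effect on these two cores in this one assay; it does not show that the same would hold on any further core, and since neither step stands beyond the scatter, it offers no effect of the methyl that could be said to transfer, only the absence of one.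

The compounds shown leave open whether a longer chain, an acetyl group or a carboxylic acid on that same ring nitrogen would leave the number as unmoved as hydrogen and methyl do. They also leave open whether the step would stay this small on a third core.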